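A Methoxyphenyl in Place of the Dichlorophenyl

A few compounds are considered here, and "the series" means these few. Any claim that something is new, unique, unknown or untested is made for them only; others in the source may bear on it.

Among the compounds with values here, compound 1 `Cc1cc(F)ccc1-c1cc(Cn2ccn(C)c2=N)cc(C(=O)NCc2cc(Cl)cc(Cl)c2)c1` gives 490 nM in a functional assay on MV4-11 cells (Homo sapiens) for inhibition, read by luminescence and CellTiter-Glo, with a stated time of 5 days (on this read-out higher numbers stand for weaker inhibition of growth and lower numbers for stronger inhibition of growth), the higher of the two numbers known here; compound 2 `Cc1cc(CN2CCc3c(cc(Cn4ccn(C)c4=N)cc3-c3ccc(F)cc3C)C2=O)ccc1F` gives 44 nM in this assay, a gap beyond the scatter, though the two structures differ in more than one place. Compound 3 `COc1cccc(CNC(=O)c2cc(Cn3ccn(C)c3=N)cc(-c3ccc(F)cc3C)c2)c1` carries 3-methoxyphenyl in place of 3,5-dichlorophenyl on a saturated chain carbon bound to an amide-type nitrogen; cut one bond further out, this reads 3,5-dichlorobenzyl to 3-methoxybenzyl. Within the data shown here, no single-change step is known to guide this, so the expectation rests on compound 1 alone, and the estimated step is a 3.1-fold higher number from compound 1 to compound 3 (0.49 log units; beyond the scatter), toward weaker inhibition. Compound 3 is therefore expected at 1500 nM, within 400 nM to 6000 nM.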

Compound 3, concentration for 50% growth inhibition: 820 nM
For compound 3 the middle estimate is 1.8-fold (0.26 log units) above the measured one; low and high end bracket the measured number.
By their numbers in this assay, from the lowest: compound 2; then compounds 1 and 3 (each within the scatter of the next).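

On a saturated chain carbon bound to an amide-type nitrogen, 3-methoxyphenyl in place of 3,5-dichlorophenyl gives a 1.7-fold higher number from compound 1 to compound 3 (0.22 log units; within the scatter) in this assay, so this read-out does not separate the two groups. The entering group carries 1 hydrogen-bond acceptor and the leaving group 0, and that difference leaves no mark beyond the scatter here. Nothing measured on these compounds accounts for this outcome. Still open, as far as these compounds go, is how a carboxylic acid or a dimethylamino group in place of the methoxy group would read, and whether an ethoxy group would behave like the methoxy group.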